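Pyridin-4-yl Replacing Difluorophenyl on the Amide Nitrogen

This account rests on a few compounds, and the source may have more. Where it says the series, first, only, none or still open, it means among the compounds named here.

Three compounds sharing one core were measured in a functional assay on HEK293 cells for positive allosteric modulation of metabotropic glutamate receptor 5 (Homo sapiens), read by calcium flux; on this read-out lower numbers stand for smaller maximal responses and higher numbers for larger maximal responses. Compound 1 `O=C1c2cc(COc3ccccc3)nn2CCN1c1cccc(F)c1` gives 81%, compound 2 `O=C1c2cc(COc3ccccc3)nn2CCN1c1ccc(F)cc1F` gives 101%, and compound 3 `COc1ccc(N2CCn3nc(COc4ccccc4)cc3C2=O)cc1` gives 58%. Compound 2 stands highest of the three, with compound 1 nearest and compound 3 furthest. The measured steps all concern the aryl group on the amide-type nitrogen in the ring: a number 20 percentage points higher from compound 1 to compound 2 (beyond the scatter), a number 23 percentage points lower from compound 1 to compound 3 (beyond the scatter), and a number 43 percentage points lower from compound 2 to compound 3 (beyond the scatter).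

Compound 4 `O=C1c2cc(COc3ccccc3)nn2CCN1c1ccncc1` is not yet measured in this assay. It differs from compound 2 in this way: pyridin-4-yl in place of 2,4-difluorophenyl on an amide-type nitrogen in a ring. The change again lies on the amide-type nitrogen, so all three measured steps bear on it; they show that this position responds to the aryl group with modest to large shifts in the maximal response, and compound 2 carries the highest value seen. Among the measured compounds shown here, no measured compound carries a heteroaromatic ring at this place, so the direction rests on the spread of the three values. Compound 4 is expected to sit below compound 2, with a step of a number 31 percentage points lower from compound 2 to compound 4 (beyond the scatter) estimated. The estimate for compound 4 is 70%, within a range of 45% to 95%.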

Compound 4, largest response reached (Emax), in percent of the reference or control that the assay uses: 72%
Beside the measured number, compound 4's estimate is 2 percentage points below it; the measured number falls inside the stated range.
By their numbers in this assay, from the lowest: compound 3; then compounds 4 and 1 (each within the scatter of the next); then compound 2.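

Compound 4 brings the first ring nitrogen into the aryl group on the amide-type nitrogen, and in this assay the pyridin-4-yl group keeps a clear response while giving up part of what the 2,4-difluorophenyl group reaches, with a number 29 percentage points lower from compound 2 to compound 4 (beyond the scatter). Among the other aryl groups the result falls in the middle ground: against 4-methoxyphenyl the comparison gives a number 14 percentage points higher from compound 3 to compound 4 (beyond the scatter), while against 3-fluorophenyl it gives a number 9 percentage points lower from compound 1 to compound 4 (within the scatter), so on this read-out the pyridin-4-yl ring cannot be told apart from the 3-fluorophenyl ring. No measurement of any property of these groups accompanies the values, so the steps stand here without an explanation.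

From the compounds shown here alone, what a pyridin-3-yl or pyridin-2-yl ring would give on this nitrogen remains open, as does the effect of adding a fluorine or a methyl group to the pyridin-4-yl ring of compound 4. Also open, going by these compounds, is whether the same order of aryl groups would hold if an amine replaced the phenoxy group of the shared core.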